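The source may hold more compounds than are shown below. What is called first, only, known or untested is meant among the compounds shown, and "the series" means these compounds.

Values in a physicochemical assay for solubility, in phosphate buffer, at pH 6.5 (a higher number here means a more soluble compound, a lower number a less soluble compound), for the series so far
compound 1 `CC(C)(C)c1ccccc1Oc1ncccc1NC(=O)Nc1ccc(C2(CO)CC2)cc1` gives 5 ug/mL
compound 2 `CN(C)Cc1cccc(-c2ccc(NC(=O)Nc3cccnc3Oc3ccccc3C(C)(C)C)c(F)c2)c1` gives 17 ug/mL
compound 3 `CC(C)(C)c1ccccc1Oc1ncccc1NC(=O)Nc1ccc(OCC2CCN(Cc3ccccc3)CC2)cc1F` gives 2 ug/mL

Compound 3 stands lowest of the three at 2 ug/mL in these notes, and its gaps to compound 1 and to compound 2 both lie beyond the scatter. For the measured compounds named here, no two measured compounds differ in one place only, so no measured step speaks directly to the next change.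

Compound 4 `CC(C)CCN1CCC(COc2ccc(NC(=O)Nc3cccnc3Oc3ccccc3C(C)(C)C)c(F)c2)CC1` departs from compound 3 in one place, with isobutyl in place of phenyl on a saturated chain carbon bound to an amine nitrogen in a ring. The count for this change reads isobutyl in place of phenyl on a saturated chain carbon bound to an amine nitrogen in a ring in full. Cut one bond further out, the same difference reads benzyl to isopentyl.

The expected step in this assay is small and upward, with a 2.0-fold higher number from compound 3 to compound 4 (0.30 log units; within the scatter) as the estimate, close to the edge of the scatter. This expectation rests on little more than compound 3 sitting at 2 ug/mL at the bottom of the measured values, which leaves a rise more likely than a further fall, and the range is kept wide for that reason. Compound 4 is estimated at 4 ug/mL with an expected range from 1.5 ug/mL to 15 ug/mL in this measurement.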

Compound 4, solubility: 87 ug/mL
For compound 4 the middle estimate is 22-fold (1.34 log units) below the measured one; the measured number lies above the stated range.
By their numbers in this assay, from the lowest: compound 3; then compound 1; then compound 2; then compound 4.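

In this assay the outer group on the saturated chain carbon bound to an amine nitrogen in a ring turns out to matter a great deal: isobutyl in place of phenyl gives a 44-fold higher number from compound 3 to compound 4 (1.64 log units; beyond the scatter) and this lies well beyond the scatter. For the compounds shown here, it is the first step that can be read at a single place, and since the rest of the structure stays the same, the whole of the step belongs to this one difference, which also reads as benzyl to isopentyl. No measurement here bears on why a change of this size appears at this position.

The change removes a six-membered aromatic ring of carbon only and also replaces it with an open branched chain, so the pair cannot separate the loss of the aromatic ring from the presence of the isobutyl group itself. Cyclohexyl at this place would keep a ring without the aromatic character, while a shorter chain such as ethyl or a longer unbranched chain would test whether the size and the branching of the group count, and the pair cannot say whether a step of this kind would carry over to the other compounds of the series.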